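The source may hold more compounds than are shown below. What is called first, only, known or untested is meant among the compounds shown, and "the series" means these compounds.

Measured so far in an ADME assay on MRC5 cells (Homo sapiens) for inhibition, with a stated time of 72 h; a higher number here means that more compound is needed for the effect, a lower number that less compound is needed:
- compound 1 `CCc1ccccc1C(=O)Nc1c[nH]nc1C(=O)N[C@H]1CC[C@H](OC)CC1`: 3400 nM
- compound 2 `COc1cccc(OC)c1C(=O)Nc1c[nH]nc1C(=O)NC1CCN(C(=O)OC(C)(C)C)CC1`: > 50000 nM (a limit of the assay, not a number)
- compound 3 `COc1cccc(OC)c1C(=O)Nc1c[nH]nc1C(=O)NCc1ccccn1`: > 50000 nM (a limit of the assay, not a number)

Going by the values given here, compound 1 is the only member of the series with a numeric value in this assay; the other two sit at the limit of > 50000 nM in this assay, at which 2 of the 3 values shown sit. Among the compounds with values here, no pair of measured compounds differs in a single place, so no measured step is available to anchor the next change.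

Compound 4 `CO[C@H]1CC[C@H](NC(=O)c2n[nH]cc2NC(=O)C2CCC(F)(F)CC2)CC1` is not yet measured. It differs from compound 1 by 4,4-difluorocyclohexyl in place of 2-ethylphenyl on a carbonyl carbon.

Within the data shown here, with no measured step to lean on, the expectation for compound 4 is a modest shift toward needing more compound, a 2.4-fold higher number from compound 1 to compound 4 (0.37 log units; beyond the scatter), not far beyond the scatter. The estimate for compound 4 in this assay is 8000 nM, with a range from 2500 nM to 40000 nM.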

Compound 4, half-maximal effective concentration: > 50000 nM
Compound 4 was reported as a limit; the forecaster's own chance of this, stated with the estimate: 30%; middle value at least 6.2-fold (0.79 log units) away from the limit.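

Going by these compounds alone, the first single-place step is large: an at least 14-fold higher number from compound 1 to compound 4 (1.16 log units; beyond the scatter), with 4,4-difluorocyclohexyl in place of 2-ethylphenyl on a carbonyl carbon. The group at this position therefore matters in this assay, since this one change takes compound 1 from a numeric value to a limit. The value of compound 4 is a limit, not a number, and it joins the others there: the limit of > 50000 nM in this assay, at which 3 of the 4 values shown sit.

On these data alone, how far the step extends past that limit remains open. It is also unclear whether the loss of the aromatic ring or the arrival of fluorine drives it, a question that a plain cyclohexyl group at this position would address.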